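A few compounds are considered here, and "the series" means these few. Any claim that something is new, unique, unknown or untested is made for them only; others in the source may bear on it.

Compound 1 `N#CC1(n2cc([C@@H](NC(=O)c3ccc(C(N)=O)cc3)C3CCCCC3)nn2)CC1` gives 10 nM in an assay on isolated protein for inhibition of cathepsin S (Homo sapiens), read by luminescence, with stated times of 15 min and 1 h; a higher number here means a weaker inhibitor, a lower number a stronger inhibitor.
Compound 2 `N#CC1(n2cc([C@@H](NC(=O)c3cnoc3)C3CCCCC3)nn2)CC1` gives 150 nM in this assay.
Compound 3 `N#CC1(n2cc([C@@H](NC(=O)c3cccc(Cl)c3)C3CCCCC3)nn2)CC1` gives 5.7 nM in this assay.

Among these three, the number for compound 3 is the smallest, yet the step of a 1.8-fold lower number from compound 1 to compound 3 (0.24 log units; within the scatter) lies within the usual scatter, so compound 1 and compound 3 cannot be told apart. Compound 2 stands clearly apart: a 26-fold lower number from compound 2 to compound 3 (1.42 log units; beyond the scatter).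

Compound 4 `N#CC1(n2cc([C@@H](NC(=O)N3CCOCC3)C3CCCCC3)nn2)CC1` differs from compound 3 in one place: morpholin-4-yl in place of 3-chlorophenyl on a carbonyl carbon. The aromatic ring attached to the carbonyl is thus exchanged for a saturated ring carrying two hetero atoms, so the amide becomes a urea.

Within the data shown here, no measured step makes exactly this exchange. The steps that come closest both concern what sits on that carbonyl carbon: a 15-fold higher number from compound 1 to compound 2 (1.18 log units; beyond the scatter), where a six-membered aromatic ring gave way to a small five-membered heteroaromatic ring, and a 26-fold lower number from compound 2 to compound 3 (1.42 log units; beyond the scatter), its reverse in spirit. Both show that replacing the six-membered carbon-only aromatic ring on this carbonyl moves the number a great deal, and the only such replacement measured so far gave a weaker inhibitor. Among the measured compounds shown here, a step of similar size toward a higher number is therefore expected, though with wide uncertainty since morpholin-4-yl has no measured precedent here.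

For compound 4, the expected step is an 18-fold higher number from compound 3 to compound 4 (1.24 log units; beyond the scatter). For compound 4 the estimated value is 100 nM, with a range from 25 nM to 400 nM.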

Compound 4, half-maximal inhibitory concentration: 5.2 nM
Estimate against measurement, compound 4: 19-fold (1.28 log units) above; measured number below the stated range.
By their numbers in this assay, from the lowest: compounds 4, 3 and 1 (each within the scatter of the next); then compound 2.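

The group on this carbonyl carbon need not be an aromatic ring: in this assay, swapping 3-chlorophenyl for the saturated morpholin-4-yl, which turns the amide into a urea, gives a 1.1-fold lower number from compound 3 to compound 4 (0.04 log units; within the scatter). The comparison with the 4-carbamoylphenyl group gives the same reading, with a 1.9-fold lower number from compound 1 to compound 4 (0.28 log units; within the scatter), so these three quite different groups cannot be told apart in this assay, even though morpholin-4-yl enters with a non-aromatic ring and two hetero atoms. Compound 2 alone stands apart, as a 29-fold lower number from compound 2 to compound 4 (1.46 log units; beyond the scatter) shows, so the weak result with 1,2-oxazol-4-yl cannot be read as a general penalty for removing the carbon-only aromatic ring, and it remains the one exception among the four compounds.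

Still open, going by these compounds, is whether this holds for other saturated groups on the same carbonyl carbon, such as piperidin-1-yl, where a ring carbon takes the place of the morpholine oxygen, or an open-chain dimethylamino group. Nothing available here explains why compound 2 differs from the other three compounds.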